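This account rests on a few compounds, and the source may have more. Where it says the series, first, only, none or still open, it means among the compounds named here.

Of the compounds shown here, three have been measured so far in a physicochemical assay for lipophilicity, using the shake flask method (on this read-out lower numbers stand for lower lipophilicity and higher numbers for higher lipophilicity), as follows.

- Compound 1 `Nc1ncnc(Oc2ccc(NC(=O)C3(C(=O)Nc4ccc(F)cc4)CC3)cc2F)c1/C=N/OCCO` (2.37)
- Compound 2 `CCOC(=O)CO/N=C/c1c(N)ncnc1Oc1ccc(NC(=O)C2(C(=O)Nc3ccc(F)cc3)CC2)cc1F` (3.15)
- Compound 3 `Nc1ncnc(Oc2ccc(NC(=O)C3(C(=O)Nc4ccc(F)cc4)CC3)cc2F)c1/C=N/OCCCN1CCCC1` (3.82)

Compound 1 stands lowest of the three, and both other compounds lie beyond the scatter from it. Compound 4 `CCCCO/N=C/c1c(N)ncnc1Oc1ccc(NC(=O)C2(C(=O)Nc3ccc(F)cc3)CC2)cc1F` has not yet been measured. It differs from compound 1 in one place, with ethyl in place of hydroxy on a saturated chain carbon, two bonds along the chain from an oxygen. The same difference, cut one bond further out, reads 2-hydroxyethyl to butyl.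

For the measured compounds named here, no measured step makes exactly this change, but two act on the same chain of compound 1. Ethoxycarbonyl in place of hydroxymethyl gives a modest step (a number 0.78 log units higher from compound 1 to compound 2 (beyond the scatter)). (Pyrrolidin-1-yl)methyl in place of hydroxy, at the same place as the change in compound 4, gives a large one (a number 1.45 log units higher from compound 1 to compound 3 (beyond the scatter)). Both go upward, so they indicate a direction and only a rough size. Resting mainly on the second of these, a large upward step is expected (a number 1.73 log units higher from compound 1 to compound 4 (beyond the scatter)). Compound 4 is estimated at 4.1 (expected range 3.5 to 4.7).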

Compound 4, partition coefficient: 4.2
The estimate for compound 4 lay 0.10 log units below the measured number, and the stated range covers the measured number.
By their numbers in this assay, from the lowest: compound 1; then compound 2; then compound 3; then compound 4.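

In this assay, ethyl in place of hydroxy on a saturated chain carbon, two bonds along the chain from an oxygen, gives a number 1.83 log units higher from compound 1 to compound 4 (beyond the scatter), and this makes compound 4 the highest of the four, with its steps to all three others beyond the scatter. The earlier compounds shown here could only show that the number rose from compound 1 when the chain carried an ester or a pyrrolidine, whereas the plain butyl chain now goes further than either: methyl in place of pyrrolidin-1-yl gives a number 0.38 log units higher from compound 3 to compound 4 (beyond the scatter), and propyl in place of ethoxycarbonyl gives a number 1.05 log units higher from compound 2 to compound 4 (beyond the scatter). Among these four compounds, then, the highest number belongs to the chain with no hydroxy, ethoxycarbonyl or pyrrolidin-1-yl group, and compound 1, with its hydroxy, stays lowest.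

Nothing given here accounts for the size of these steps. The compounds shown leave open whether a longer chain such as hexyl would rise further above compound 4, and where a carboxylic acid or a smaller amine such as dimethylamino at the end of the chain would fall.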